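Shortening the side chain of a melatonin receptor ligand

A few compounds are considered here, and "the series" means these few. Any claim that something is new, unique, unknown or untested is made for them only; others in the source may bear on it.

Compound 1 `CCC(=O)NCCCc1cc2c(OC)cccc2n1-c1ccccc1` was examined in an assay on NIH3T3 cells for binding affinity to melatonin receptor type 1B (Homo sapiens) (on this read-out higher numbers stand for weaker inhibition and lower numbers for stronger inhibition), where compound 1 gives 12.9 nM. Among the measured compounds shown here, of the two numbers known here this is the lowest; the other belongs to compound 2 `COc1ccc2[nH]c(CCCNC(C)=O)cc2c1`, which in this assay gives 102000 nM, a far weaker result that lies well beyond the usual scatter. Compound 3 `CCC(=O)NCc1cc2c(OC)cccc2n1-c1ccccc1` has not been measured. It differs from compound 1 in one place: propanoylamino in place of 2-(propanoylamino)ethyl on a saturated chain carbon bound to an aromatic carbon. The shared core and the amide end stay the same, and only the chain between them becomes shorter. For the measured compounds named here, with no measured step of this kind to lean on, the expectation rests on compound 1 alone. Affinity is expected to fall, with a step of a 23-fold higher number from compound 1 to compound 3 (1.37 log units; beyond the scatter) that reaches beyond the scatter. Compound 3 is therefore estimated at 300 nM, within a range from 40 nM to 3000 nM.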

Compound 3, inhibition constant: 10.2 nM
The estimate for compound 3 lay 29-fold (1.47 log units) above the measured number, outside the stated range (below it).
By their numbers in this assay, from the lowest: compounds 3 and 1 (each within the scatter of the next); then compound 2.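

In this assay, putting propanoylamino in place of 2-(propanoylamino)ethyl on this saturated chain carbon gives a 1.3-fold lower number from compound 1 to compound 3 (0.10 log units; within the scatter), so this read-out does not separate the two compounds. Before this result, compound 1 alone spoke for this series, and nothing showed how much the chain length at this position mattered. This pair shows that the chain joining the shared core to the amide end can be cut from 3-(propanoylamino)propyl to (propanoylamino)methyl with the number staying within the usual scatter, so this stretch of chain can be shortened without a measurable loss on this read-out.

Going by these compounds, whether a longer chain, or an amine in place of the amide end, would hold the same affinity remains open. No measurement at hand explains why the two chain lengths read alike.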